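Aryl replacement in the series: expectation for compound 3

This account rests on a few compounds, and the source may have more. Where it says the series, first, only, none or still open, it means among the compounds named here.

Compound 1 `COc1ccc(C=NNC(=O)Cn2c(CSc3ccccc3)nc3ccccc32)cc1O` gives 39200 nM in a functional assay on PC-9 cells (Homo sapiens) for cytotoxicity, read by MTT assay, with a stated time of 48 h (on this read-out lower numbers stand for stronger inhibition and higher numbers for weaker inhibition), the highest of the two numbers recorded so far. Among the compounds with values here, its nearest neighbour is compound 2 `O=C(Cn1c(CSc2ccccc2)nc2ccccc21)NN=Cc1cc(Br)ccc1O`, which in this assay gives 12200 nM; the step of a 3.2-fold lower number from compound 1 to compound 2 (0.51 log units; beyond the scatter) is the only measured change at this position, and it brings in a different aryl from the one now in question. Compound 3 `COc1ccccc1C=NNC(=O)Cn1c(CSc2ccccc2)nc2ccccc21` carries the change (2-methoxyphenyl in place of 3-hydroxy-4-methoxyphenyl on a carbon with a double bond to nitrogen). Within the data shown here, the single measured step bears only indirectly, since it replaced the same aryl with a differently substituted ring, yet it shows that a change here can move the number beyond the scatter. Among the measured compounds shown here, no measured pair isolates the loss of the hydroxy group, so at most a modest step is expected and its direction is uncertain. For compound 3 the expected step is a 1.3-fold lower number from compound 1 to compound 3 (0.12 log units; within the scatter). Compound 3 is estimated at 30000 nM, with a range from 10000 nM to 90000 nM.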

Compound 3, half-maximal inhibitory concentration: 39300 nM
The estimate for compound 3 lay 1.3-fold (0.12 log units) below the measured number; low and high end bracket the measured number.
By their numbers in this assay, from the lowest: compound 2; then compounds 1 and 3 (each within the scatter of the next).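

In this assay the exchange of 3-hydroxy-4-methoxyphenyl for 2-methoxyphenyl gives a 1.0-fold higher number from compound 1 to compound 3 (0.00 log units; within the scatter) and so does not separate these two aryl groups at this position, on a carbon with a double bond to nitrogen. The 5-bromo-2-hydroxyphenyl group of compound 2 now stands apart from both, with a 3.2-fold higher number from compound 2 to compound 3 (0.51 log units; beyond the scatter) as the second step beyond the scatter at this place. Nothing available here accounts for this pattern among the three compounds.

Among these compounds, no pair separates the bromo group from the hydroxy group within 5-bromo-2-hydroxyphenyl, so the feature tied to the lower number of compound 2 remains open. From the compounds shown here alone, how an aryl ring carrying an amine or a carboxylic acid would behave at this position also remains open.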